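A few compounds are considered here, and "the series" means these few. Any claim that something is new, unique, unknown or untested is made for them only; others in the source may bear on it.

Measured so far in a physicochemical assay for solubility, in phosphate buffer, at pH 7.4; on this read-out lower numbers stand for lower solubility and higher numbers for higher solubility:
compound 1, `CCOC(=O)c1c(-c2cccc(C(F)(F)F)c2)[nH]c2cc(OC)ccc2c1=O`, 19000 nM
compound 2, `CCOC(=O)c1c(-c2ccccc2C)[nH]c2cc(OC)ccc2c1=O`, > 100000 nM

Compound 2 stands at the upper edge of the scale: the value > 100000 nM for compound 2 in this assay is a limit, not a number, namely (the limit of > 100000 nM in this assay, at which 1 of the 2 values shown sits). Compound 1 gives a number, 19000 nM, so of the two only compound 1 is placed on the scale. Within the data shown here, no step between measured compounds is counted here; the two values show only that compound 2 sits at the limit and compound 1 does not.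

Compound 3, `CCOC(=O)c1c(-c2cccc(Cl)c2)[nH]c2cc(OC)ccc2c1=O`, is not yet measured. It differs from compound 2 by 3-chlorophenyl in place of 2-methylphenyl on an aromatic carbon. Since compound 1, with a trifluoromethyl on its phenyl, gives 19000 nM, a downward step from compound 2 is expected, of size an at least 2.5-fold lower number from compound 2 to compound 3 (0.39 log units; beyond the scatter). For compound 3 the expected solubility in this assay is 40000 nM, with a range from 12000 nM to 120000 nM.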

Compound 3, solubility: 58000 nM
Beside the measured number, compound 3's estimate is 1.5-fold (0.16 log units) below it, within the range that was stated.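

In this assay, among these compounds, chloro in place of trifluoromethyl on the same aromatic carbon gives a 3.1-fold higher number from compound 1 to compound 3 (0.48 log units; beyond the scatter), so a single substituent on this phenyl now separates two measured numbers, a difference the earlier compounds could not show. Against the 2-methylphenyl compound, 3-chlorophenyl gives an at least 1.7-fold lower number from compound 2 to compound 3 (0.23 log units; that floor lies within the scatter), so the floor of this step alone does not establish a change beyond the scatter. Compound 2 remains a limit and not a number: the limit of > 100000 nM in this assay, at which 1 of the 3 values shown sits.

As far as these compounds go, whether the step from compound 2 follows the place of the substituent or its kind stays open, as both change together in that comparison. Also open, from the compounds shown here alone, is how this read-out responds to a 3-methylphenyl, or to an amine or a carboxylic acid on the phenyl ring.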